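The compounds below may be only part of what the source reports. "The series", "measured", "known", "first", "only" and "open" are said of these compounds alone.

Compound 1, `NC(=S)Nc1cccc(OCCCCCCCc2ccccc2)c1`, in an ADME assay on Ava5 cells (Homo sapiens) for cytotoxicity (a lower number here means that less compound is tolerated, a higher number that more compound is tolerated), gives 23000 nM.
Compound 2, `NC(=S)Nc1cccc(OCCCCCOc2ccc(Br)cc2)c1`, in this assay gives 19000 nM.
Compound 3, `COc1ccc(OCCCCCOc2cccc(NC(N)=S)c2)cc1`, in this assay gives only a limit of the assay, > 50000 nM.

Among the compounds with values here, compound 3 therefore stands not at a number but at the limit of this assay, the only one of the three values to do so (the limit of > 50000 nM in this assay, at which 1 of the 3 values shown sits). Compound 4, `NC(=S)Nc1cccc(OCCCCCOc2ccncc2)c1`, is not yet measured in this assay; it differs from compound 3 in one place: pyridin-4-yl in place of 4-methoxyphenyl on an oxygen on a saturated carbon. Within the data shown here, two measured steps bear on this change. The nearer one is an at least 2.6-fold higher number from compound 2 to compound 3 (0.42 log units; beyond the scatter), which also altered the outer aromatic ring of the chain and moved the number up to the limit. The other, a 1.2-fold lower number from compound 1 to compound 2 (0.08 log units; within the scatter), exchanged the whole end of the chain and left the number where it was. Neither step involves a ring with a nitrogen in it, so the step to compound 4 is not directly covered. Compound 3 sits at the limit > 50000 nM. For compound 4 a number near that limit is expected, an estimate of 45000 nM with a range from 20000 nM to 100000 nM. This estimate means a step of an at least 1.1-fold lower number from compound 3 to compound 4 (0.04 log units; that floor lies within the scatter), which is expected to remain within the scatter.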

Compound 4, half-maximal cytotoxic concentration: > 50000 nM
Compound 4 gave a limit, no number; the forecaster's own chance of this, stated with the estimate: 50%; middle value at least 1.1-fold (0.04 log units) from the limit.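

In this assay compound 4 gives > 50000 nM, which is a limit of the assay and not a number, so pyridin-4-yl, a six-membered aromatic ring with a hetero atom, can take the place of 4-methoxyphenyl on the oxygen on a saturated carbon with the value still at that limit. Compound 3 and compound 4 both stand at a limit, so the step between them cannot be read, and no order of the two can be given. What can be read is an at least 2.6-fold higher number from compound 2 to compound 4 (0.42 log units; beyond the scatter) and an at least 2.1-fold higher number from compound 1 to compound 4 (0.33 log units; beyond the scatter), so the high end of this small set no longer rests on compound 3 alone: the limit of > 50000 nM in this assay, at which 2 of the 4 values shown sit.

On these data alone, how far past the limit compound 3 and compound 4 lie stays open, and so does whether their two end groups differ at all in this assay. Also open, as far as these compounds go, is whether an amine or a carboxylic acid on the outer ring, or a longer chain carrying pyridin-4-yl, would keep the value at the limit or bring it back to a measurable number.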